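A few compounds are considered here, and "the series" means these few. Any claim that something is new, unique, unknown or untested is made for them only; others in the source may bear on it.

The two compounds measured so far in a functional assay on cells (Cancer cell lines, Homo sapiens) for inhibition, read by MTT assay, with a stated time of 48 h (on this read-out lower numbers stand for stronger inhibition and higher numbers for weaker inhibition), are these:

compound 1 `O=C(/C=C/c1ccc(Br)cc1)NNC(=O)c1ccc2c(c1)OCCO2` with 2330 nM
compound 2 `O=C(/C=C/c1cccc([N+](=O)[O-])c1)NNC(=O)c1ccc2c(c1)OCCO2` with 1560 nM

For the measured compounds named here, compound 2 has the lowest of the two numbers, but its only neighbour is compound 1, and the gap between the two is within the scatter, so neither can be called the stronger inhibitor. Going by the values given here, the sole measured step, a 1.5-fold lower number from compound 1 to compound 2 (0.17 log units; within the scatter), is also the only comparison that bears on the new compound.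

Compound 3 `O=C(/C=C/c1ccc(F)cc1)NNC(=O)c1ccc2c(c1)OCCO2` differs from compound 2 in one place: 4-fluorophenyl in place of 3-nitrophenyl on a double-bonded chain carbon bound to a double-bonded chain carbon. Among the compounds with values here, the one step that bears on this change also exchanged one substituted phenyl for another at the same place, and it stayed within the scatter. On that basis no step beyond the scatter is expected in this assay, and a number near that of compound 1 seems about as likely as one near that of compound 2. The estimate for compound 3 is therefore 2200 nM, with a range from 1000 nM to 5000 nM. That estimate means an expected step of a 1.4-fold higher number from compound 2 to compound 3 (0.15 log units; within the scatter).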

Compound 3, half-maximal inhibitory concentration: 990 nM
Estimate against measurement, compound 3: 2.2-fold (0.35 log units) above, and the stated range ends above it.
By their numbers in this assay, from the lowest: compounds 3, 2 and 1 (each within the scatter of the next, the first and the last beyond it).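

In this assay, for the compounds shown here, the fluoro and bromo pair gives the first step beyond the scatter, a modest one: a 2.4-fold lower number from compound 1 to compound 3 (0.37 log units; beyond the scatter), with fluoro in place of bromo on an aromatic carbon, so a single substituent on this phenyl ring can shift the read-out, which the earlier pair of compounds could not show. The other new step, a 1.6-fold lower number from compound 2 to compound 3 (0.20 log units; within the scatter), stays within the scatter, so 4-fluorophenyl and 3-nitrophenyl cannot be told apart here, although only the 3-nitrophenyl group carries hydrogen-bond acceptors and a double bond outside the aromatic ring. Going by these compounds alone, nothing at hand accounts for either step, and the data show only that the numbers differ.

The compounds shown leave open how an unsubstituted phenyl, or a phenyl bearing an amine or a methoxy group, would read at this same place, and so whether the fluoro compound's number belongs to fluoro itself or merely to the absence of bromo. They also leave open whether a longer chain in place of the double-bonded chain carbons would keep the numbers of compound 2 and compound 3 within the scatter of each other.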